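The source may report more compounds than this note shows. Statements on the series, on what has been measured and on what is new or still open speak of the compounds shown alone.

Measured compounds:
compound 1, `COc1ccc(-c2cc3nccc(-c4cc(OC)c(OC)c(OC)c4)n3n2)cc1N`: 251 nM
compound 2, `COc1cc(-c2ccnc3cc(-c4ccc(C)cc4)nn23)cc(OC)c1OC`: 48 nM

Within the data shown here, compound 1 holds the highest of the two numbers in a functional assay on HCT-116 cells (Homo sapiens) for inhibition, read by CCK-8 assay, with a stated time of 48 h; a lower number here means a stronger inhibitor, a higher number a weaker inhibitor; its nearest neighbour is compound 2, reached by the single recorded step, a 5.2-fold lower number from compound 1 to compound 2 (0.72 log units; beyond the scatter), which swaps the whole aryl group. Compound 3, `COc1ccc(-c2cc3nccc(-c4cc(OC)c(OC)c(OC)c4)n3n2)cc1[N+](=O)[O-]`, is not yet measured. It differs from compound 1 in one place: nitro in place of amino on an aromatic carbon. Among the measured compounds shown here, no measured step concerns this nitro-for-amino exchange; the only step in hand exchanges the entire 3-amino-4-methoxyphenyl for 4-methylphenyl and so does not speak to a change confined to one substituent. With nothing bearing directly on the change, the step from compound 1 to compound 3 is expected to stay roughly within the scatter, a 1.2-fold higher number from compound 1 to compound 3 (0.08 log units; within the scatter), with no confident direction. Compound 3 is therefore estimated at 300 nM, in the range 100 nM to 900 nM.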

Compound 3, half-maximal inhibitory concentration: > 10000 nM
Compound 3: a limit, no number (the forecaster's own chance of this, stated with the estimate: 5%); middle value at least 33-fold (1.52 log units) from the limit.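

Nitro in place of amino at this position, on an aromatic carbon ortho to a methoxy group, gives an at least 39-fold higher number from compound 1 to compound 3 (1.60 log units; beyond the scatter), so a change confined to one substituent is enough for a large step, where the earlier compounds showed only an exchange of the whole aryl group. In this assay compound 3 reads > 10000 nM, which is a limit of the assay and not a number. The step therefore gives a bound and not a full size: the limit of > 10000 nM in this assay, at which 1 of the 3 values shown sits.

The compounds shown leave open whether the step follows from the amino leaving or from the nitro entering. A hydroxyl, an acetamide or a plain hydrogen at this position on the core of compound 1 would separate the two.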